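The compounds below may be only part of what the source reports. "The series", "measured", "known", "first", "only" and "open" are said of these compounds alone.

Measured so far:
compound 1 `Cn1c(N2N=C(c3ccc(Cl)cc3)CC2c2ccccc2)nc(-c2ccccc2)c(C#N)c1=O` — 12300 nM
compound 2 `Cn1c(N2N=C(c3ccccc3)CC2c2ccccc2)nc(-c2ccc(Cl)cc2)c(C#N)c1=O` — 34400 nM

In a functional assay on MCF7 cells (Homo sapiens) for antiproliferative activity, with a stated time of 72 h (a lower number here means a stronger inhibitor, a higher number a weaker inhibitor), compound 2 gives the highest of the two numbers; compound 1 gives the lower one, and the gap between them lies beyond the scatter. Within the data shown here, no single-point step between compound 1 and compound 2 is available, so only their two values can be compared.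

Compound 3 `Cn1c(N2N=C(c3ccc(Cl)cc3)CC2c2ccccc2)nc(-c2ccc(Cl)cc2)c(C#N)c1=O` is not yet measured. It arises from compound 2 by chloro in place of hydrogen on an aromatic carbon. Since compound 1 already carries this chloro and sits lower, a modest downward step is expected, estimated as a 1.7-fold lower number from compound 2 to compound 3 (0.24 log units; within the scatter). Compound 3 is therefore expected at 20000 nM, within 7000 nM to 60000 nM.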

Compound 3, half-maximal inhibitory concentration: 25300 nM
Beside the measured number, compound 3's estimate is 1.3-fold (0.10 log units) below it, and the stated range covers the measured number.
By their numbers in this assay, from the lowest: compound 1; then compounds 3 and 2 (each within the scatter of the next).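

In this assay, adding chloro to the phenyl that compound 2 carries, phenyl to 4-chlorophenyl, gives a 1.4-fold lower number from compound 2 to compound 3 (0.13 log units; within the scatter), so this position does not separate the two compounds. The same change on the other phenyl gives a 2.1-fold higher number from compound 1 to compound 3 (0.31 log units; beyond the scatter), a modest step, so a second chloro does not add to the effect of the first in this pair. Nothing available explains the difference between these two steps.

Going by these compounds, whether a methoxy group, an amine or a carboxylic acid at this position would shift the value remains open. Fluoro and bromo in place of chloro are equally open.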